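One Carbon Longer on the Side Chain

A few compounds are considered here, and "the series" means these few. Any claim that something is new, unique, unknown or untested is made for them only; others in the source may bear on it.

Of the compounds shown here, three with a shared core have been tested in a functional assay on HEL cells (Homo sapiens), read by microscopy; a higher number here means that more compound is tolerated, a lower number that less compound is tolerated. Compound 1 `CCCCCCCC#Cc1cc2cn(COCCO)c(=O)nc2o1` gives 200000 nM. Compound 3 `CCCCCCCCCCCc1cc2cn(COCCO)c(=O)nc2o1` gives 80000 nM. Compound 2 `CCCCCCCc1cc2cn(COCCO)c(O)nc-2n1` reaches only a limit of the assay, >= 400000 nM, so no exact number is known for it. Among the three values shown, compound 2 sits at the limit (the limit of >= 400000 nM in this assay, at which 1 of the 3 values shown sits), while compound 1 and compound 3 both lie below that limit.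

Compound 4 `CCCCCCCCc1cc2cn(COCCO)c(O)nc-2n1` is the next compound to be measured in this assay. It differs from compound 2 in one place: methyl in place of hydrogen on a saturated chain carbon, seven bonds along the chain from an aromatic carbon. The chain thus grows by one carbon, with nothing else changed.

Among the measured compounds shown here, no step between two measured compounds is available here, so the effect of a single carbon added to this chain can only be guessed. The values of compound 1 and compound 3 show that the compound with the longer chain tolerates less, but those two differ in more than one way. For compound 4 the step of an at least 1.3-fold lower number from compound 2 to compound 4 (0.12 log units; that floor lies within the scatter) is expected to be small and, if anything, toward less tolerated. Compound 4 is therefore estimated at 300000 nM, with a likely range from 120000 nM to 450000 nM.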

Compound 4, minimum cytotoxic concentration: 80000 nM
Compound 4: middle estimate off by 3.8-fold (0.57 log units), on the high side, outside the stated range (below it).
By their numbers in this assay, from the lowest: compounds 3 and 4 (each within the scatter of the next); then compound 1. At a limit, above all of these: compound 2.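

In this assay, methyl in place of hydrogen on a saturated chain carbon, seven bonds along the chain from an aromatic carbon, gives an at least 5.0-fold lower number from compound 2 to compound 4 (0.69 log units; beyond the scatter). Among the compounds shown here, this is the only step here between compounds that differ in one place, and it shows that one added carbon at this position is enough to move the tolerated concentration beyond the usual scatter. The size of the step is only a floor, since compound 2 has a limit of the assay and not a number: the limit of >= 400000 nM in this assay, at which 1 of the 4 values shown sits.

From the compounds shown here alone, what remains open is how far this trend runs along the chain on this core. A longer chain in place of this methyl might lower the number further or leave it unchanged, and an amine or a carboxylic acid at this place could behave quite differently.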